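Aryl amine variation on a shared core: next step

The compounds below may be only part of what the source reports. "The series", "measured", "known", "first", "only" and "open" are said of these compounds alone.

The series keeps one shared core and changes only the aryl group on the ring nitrogen. Compound 1 `N#Cc1c(Nc2cccc(C(F)(F)F)c2)nc(SCc2cn(Cc3ccccc3Cl)nn2)nc1-c1ccccc1` gives 22800 nM in a functional assay on MGC-803 cells (Homo sapiens) for inhibition, read by MTT assay, with a stated time of 72 h; on this read-out higher numbers stand for weaker inhibition and lower numbers for stronger inhibition. Compound 2 `N#Cc1c(Nc2ccc(Cl)cc2)nc(SCc2cn(Cc3ccccc3Cl)nn2)nc1-c1ccccc1` gives 5850 nM in this assay, and compound 3 `N#Cc1c(Nc2cccc(Cl)c2)nc(SCc2cn(Cc3ccccc3Cl)nn2)nc1-c1ccccc1` gives 15800 nM. Compound 3 therefore stands second highest of the three numbers: its gap to compound 1 is within the scatter, while compound 2 sits clearly lower, as the step of a 2.7-fold higher number from compound 2 to compound 3 (0.43 log units; beyond the scatter) shows.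

Compound 4 `COc1ccccc1Nc1nc(SCc2cn(Cc3ccccc3Cl)nn2)nc(-c2ccccc2)c1C#N` differs from compound 3 in one place: 2-methoxyphenyl in place of 3-chlorophenyl on a nitrogen on an aromatic ring.

Within the data shown here, the steps that bear on this change are the two earlier swaps of the whole aryl group, a 3.9-fold lower number from compound 1 to compound 2 (0.59 log units; beyond the scatter) and a 2.7-fold higher number from compound 2 to compound 3 (0.43 log units; beyond the scatter), both modest and beyond the scatter, whereas the single-group exchange a 1.4-fold lower number from compound 1 to compound 3 (0.16 log units; within the scatter) stayed within the scatter. Among the measured compounds shown here, no measured step introduces a methoxy group or a 2-substituted ring, so the direction for compound 4 is not fixed by the data; a modest move either way, or none beyond the scatter, remains open.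

Compound 4 is estimated at 12000 nM in this assay, with a range from 4000 nM to 40000 nM. The expected step is a 1.3-fold lower number from compound 3 to compound 4 (0.12 log units; within the scatter).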

Compound 4, half-maximal inhibitory concentration: 5800 nM
Estimate against measurement, compound 4: 2.1-fold (0.32 log units) above; measured number inside the range.
By their numbers in this assay, from the lowest: compounds 4 and 2 (each within the scatter of the next); then compounds 3 and 1 (each within the scatter of the next).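

In this assay, 4-chlorophenyl alone had stood apart from the other aryl groups on this nitrogen, but 2-methoxyphenyl now shares its level, with a 1.0-fold lower number from compound 2 to compound 4 (0.00 log units; within the scatter), so among the compounds shown that level does not depend on a chloro group. The same exchange changes the read-out beyond the scatter against the two other aryl groups, with a 2.7-fold lower number from compound 3 to compound 4 (0.44 log units; beyond the scatter) and a 3.9-fold lower number from compound 1 to compound 4 (0.59 log units; beyond the scatter), which shows that this position tolerates a change of both substituent and its place on the ring without a loss relative to compound 2. Nothing measured here explains these steps or the match between compound 2 and compound 4.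

The compounds shown leave open whether the level of compound 4 follows the methoxy group itself or its place on the ring, a question that 2-chlorophenyl and 4-methoxyphenyl on the same nitrogen would separate. They also leave open how far the level holds for 2-hydroxyphenyl or for the longer 2-ethoxyphenyl group.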